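Notes on compound 4: carboxymethoxy variant of compound 3

The source may report more compounds than this note shows. Statements on the series, on what has been measured and on what is new or still open speak of the compounds shown alone.

Three compounds of the series have numbers in an assay on HeLa cells for inhibition of Indoleamine 2,3-dioxygenase 1 (Homo sapiens), read by spectrophotometry, with a stated time of 24 h; a higher number here means that more compound is needed for the effect, a lower number that less compound is needed. Compound 1 `CC(=O)Nc1ccc(S(=O)(=O)NNc2ccc(Br)cc2)cc1` gives 85 nM; compound 2 `N#Cc1ccc(S(=O)(=O)NNc2ccc(Br)cc2)cc1` gives 134 nM; compound 3 `COC(=O)CCc1ccc(S(=O)(=O)NNc2ccc(Br)cc2)cc1` gives 465 nM. Compound 3 therefore stands highest of the three, with a 3.5-fold higher number from compound 2 to compound 3 (0.54 log units; beyond the scatter) and a 5.5-fold higher number from compound 1 to compound 3 (0.74 log units; beyond the scatter), both steps beyond the scatter but modest in size, while a 1.6-fold higher number from compound 1 to compound 2 (0.20 log units; within the scatter) lies within the scatter.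

Compound 4 `O=C(O)COc1ccc(S(=O)(=O)NNc2ccc(Br)cc2)cc1` differs from compound 3 in one place: carboxymethoxy in place of 2-(methoxycarbonyl)ethyl on an aromatic carbon. Going by the values given here, no measured step covers this exact exchange. Among the compounds with values here, the steps that bear on it are those into compound 3, which show that swapping the group at this position has so far moved the number only modestly in this assay. Compound 4 is therefore expected to sit near compound 3, with a 1.2-fold lower number from compound 3 to compound 4 (0.07 log units; within the scatter) most likely inside the scatter and no direction claimed with confidence. The estimate for compound 4 in this assay is 400 nM, with a range from 140 nM to 1200 nM.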

Compound 4, half-maximal effective concentration: 152 nM
Compound 4: middle estimate off by 2.6-fold (0.42 log units), on the high side; the measured number falls inside the stated range.
By their numbers in this assay, from the lowest: compounds 1, 2 and 4 (each within the scatter of the next); then compound 3.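

In this assay the exchange of 2-(methoxycarbonyl)ethyl for carboxymethoxy gives a 3.1-fold lower number from compound 3 to compound 4 (0.49 log units; beyond the scatter) and shows that this position, para to a large group, accepts a chain ending in a hydrogen-bond donor without a rise in the number. Set against the other groups, a 1.1-fold higher number from compound 2 to compound 4 (0.05 log units; within the scatter) and a 1.8-fold higher number from compound 1 to compound 4 (0.25 log units; within the scatter) are both within the scatter, so carboxymethoxy, cyano and acetamido cannot be ordered, and 2-(methoxycarbonyl)ethyl in compound 3 is the only group so far that stands apart from the rest. No measurement is available that would account for the difference between compound 3 and compound 4.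

Going by these compounds, the exchange alters the chain and its end together, so it remains open which of these changes matters. The methyl ester of the carboxymethoxy group and the carboxylic acid of the 2-(methoxycarbonyl)ethyl chain would separate the two, and an amine at this position remains an open case.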